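From Cyclopropylsulfonyl to (Pyridin-3-yl)carbonyl on a Ring Nitrogen

A few compounds are considered here, and "the series" means these few. Any claim that something is new, unique, unknown or untested is made for them only; others in the source may bear on it.

Measured so far in a physicochemical assay for lipophilicity, measured as octanol-water partition, at pH 7.4; on this read-out lower numbers stand for lower lipophilicity and higher numbers for higher lipophilicity:
- Compound 1 `Cc1ccc2[nH]c(C(=O)N[C@H]3CN(S(=O)(=O)c4ccccc4)C[C@@H]3C(=O)NCCN(C)C)cc2c1` gives 2.1
- Compound 2 `Cc1ccc2[nH]c(C(=O)N[C@H]3CCN(S(=O)(=O)C4CC4)C[C@@H]3C(=O)NCCN(C)C)cc2c1` gives 1

Of these two, compound 2 stands lowest at 1. Its nearest neighbour on the numbers is compound 1 at 2.1, which lies higher, a gap beyond the usual scatter. Within the data shown here, the two compounds differ in more than one place, and no measured pair isolates a single change.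

Compound 3 `Cc1ccc2[nH]c(C(=O)N[C@H]3CCN(C(=O)c4cccnc4)C[C@@H]3C(=O)NCCN(C)C)cc2c1` has not yet been measured in this assay. Relative to compound 2, it carries (pyridin-3-yl)carbonyl in place of cyclopropylsulfonyl on an amine nitrogen in a ring. Among the measured compounds shown here, no measured step covers this exchange, so the expectation starts from compound 2 at 1 and stays cautious: a small downward move at most, probably not beyond the usual scatter. The estimated change is a number 0.10 log units lower from compound 2 to compound 3 (within the scatter). Compound 3 is expected at 0.9, with an estimated range of 0.4 to 1.4.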

Compound 3, distribution coefficient: 0.7
For compound 3 the middle estimate is 0.20 log units above the measured one, within the range that was stated.
By their numbers in this assay, from the lowest: compounds 3 and 2 (each within the scatter of the next); then compound 1.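

Among these compounds, the exchange of cyclopropylsulfonyl for (pyridin-3-yl)carbonyl on an amine nitrogen in a ring gives the first step in this assay that isolates a single place, a number 0.30 log units lower from compound 2 to compound 3 (within the scatter). At this position, then, a sulfonyl bearing a three-membered carbon ring gave way to a carbonyl bearing a six-membered aromatic ring with 1 hetero atom, 8 heavy atoms entering against 6 leaving, and the read-out did not move beyond the usual scatter, although linker and ring changed together. Nothing at hand explains the size of this step, and compound 1 differs from compound 3 in more than one place, so it adds nothing to this reading.

Among the compounds shown here, the single step cannot say how the linker and the ring each contribute, a question that phenylsulfonyl or cyclopropylcarbonyl on the same nitrogen would separate. Also open, from the compounds shown here alone, is how simpler groups there, such as acetyl or benzoyl, would read in this assay, and whether the same exchange would give a similar step on the core of compound 1.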